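The source may hold more compounds than are shown below. What is called first, only, known or untested is meant among the compounds shown, and "the series" means these compounds.

Three measured compounds share one core and differ only in the aryl group that hangs from an oxygen on an aromatic ring. Compound 1 `Cc1ccccc1Oc1cccc(COc2ccccc2CCC(=O)OCCCOP(=O)(O)OC[C@H](N)C(=O)O)c1` carries 2-methylphenyl there; in an assay on cells for agonist activity at probable G-protein coupled receptor 34 (Mus musculus), with a stated time of 1 h (on this read-out higher numbers stand for larger maximal responses and lower numbers for smaller maximal responses), compound 1 gives 20.3%. Compound 2 `Cc1ccc(Oc2cccc(COc3ccccc3CCC(=O)OCCCOP(=O)(O)OC[C@H](N)C(=O)O)c2)cc1` carries 4-methylphenyl, and in this assay compound 2 gives 18.2%. Compound 3 `N[C@@H](COP(=O)(O)OCCCOC(=O)CCc1ccccc1OCc1cccc(Oc2ccc(Br)cc2)c1)C(=O)O` carries 4-bromophenyl, and in this assay compound 3 gives 17.7%. The three numbers sit together: a number 2.1 percentage points lower from compound 1 to compound 2 (within the scatter), a number 2.6 percentage points lower from compound 1 to compound 3 (within the scatter) and a number 0.5 percentage points lower from compound 2 to compound 3 (within the scatter), each within the scatter, so compound 3 is not set apart from compound 1 or compound 2 by these data.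

Compound 4 `CC(C)(C)c1ccc(Oc2cccc(COc3ccccc3CCC(=O)OCCCOP(=O)(O)OC[C@H](N)C(=O)O)c2)cc1` is the next step from compound 3. The change is tert-butyl in place of bromo on an aromatic carbon. Among the compounds with values here, the one measured step at the same position, bromo in place of methyl, is a number 0.5 percentage points lower from compound 2 to compound 3 (within the scatter), and the other swaps of the aryl group, a number 2.1 percentage points lower from compound 1 to compound 2 (within the scatter) and a number 2.6 percentage points lower from compound 1 to compound 3 (within the scatter), are no larger. Within the data shown here, no measured step therefore bears on this change beyond the scatter, and the step to compound 4 is expected to be no larger, with a number 0.3 percentage points higher from compound 3 to compound 4 (within the scatter) the estimated change. Compound 4 is estimated to give 18% in this assay, within 9% to 28%.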

Compound 4, largest response reached (Emax), in percent of the reference or control that the assay uses: 16.9%
For compound 4 the middle estimate is 1.1 percentage points above the measured one, and the stated range covers the measured number.
By their numbers in this assay, from the lowest: compounds 4, 3, 2 and 1 (each within the scatter of the next).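

Placing tert-butyl, four carbon heavy atoms in place of one bromine, on this aromatic carbon para to a large group does not set compound 4 apart in this assay: the read-out shows a number 0.8 percentage points lower from compound 3 to compound 4 (within the scatter) and, against the methyl analogue, a number 1.3 percentage points lower from compound 2 to compound 4 (within the scatter). Even the largest step now available, a number 3.4 percentage points lower from compound 1 to compound 4 (within the scatter), which exchanges 2-methylphenyl for 4-(tert-butyl)phenyl, stays within the scatter, so methyl, bromo and tert-butyl at this carbon and the 2-methylphenyl variant cannot be told apart by these four compounds. No supporting data are available to explain why these substitutions leave the compounds indistinguishable.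

On these data alone, whether an amine, a hydroxyl or a carboxylic acid on this aromatic carbon would give a maximal response beyond the scatter of these four compounds remains open. Also open is whether a change outside this aryl group, such as a longer chain on the ester oxygen of the shared core, would separate a compound from this set, and the maximal responses shown say nothing about the concentrations at which these compounds act.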